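Fluoro to methyl on the aryl ring: expected step

The source may report more compounds than this note shows. Statements on the series, on what has been measured and on what is new or still open speak of the compounds shown alone.

Compound 1 `COC(=O)c1cc(-c2csc(N/N=C/c3cccs3)n2)ccc1OCc1ccccc1` gives 96% in a functional assay, read by spectrophotometry, with a stated time of 15 min, tested at 80 ug/mL; on this read-out higher numbers stand for a stronger effect at the one concentration tested and lower numbers for a weaker effect. Compound 2 `Clc1ccc(-c2csc(N/N=C/c3cccs3)n2)cc1` gives 96.6%. Compound 3 `Fc1ccc(-c2csc(N/N=C/c3ccc(Cl)cc3Cl)n2)cc1` gives 95.5%, the lowest of the three numbers, yet compound 1 lies nearest and compound 2 furthest, both within the scatter, so no order among the three can be read. Compound 4 `Cc1ccc(-c2csc(N/N=C/c3ccc(Cl)cc3Cl)n2)cc1` differs from compound 3 by methyl in place of fluoro on an aromatic carbon, a change from 4-fluorophenyl to 4-methylphenyl. Among the measured compounds shown here, no step between measured compounds is available; because compound 2 gives 96.6% and compound 3 gives 95.5% despite wider differences, the step from compound 3 to compound 4 is expected to stay within the scatter, a number 0.5 percentage points lower from compound 3 to compound 4 (within the scatter). Compound 4 is estimated at 95%, between 89% and 99%.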

Compound 4, a percentage reported as inhibition, at one concentration (the size of the read-out at that concentration, not a potency): 90.7%
Beside the measured number, compound 4's estimate is 4.3 percentage points above it; low and high end bracket the measured number.
By their numbers in this assay, from the lowest: compounds 4, 3, 1 and 2 (each within the scatter of the next).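

Among the compounds shown here, compounds 3 and 4 form the first pair that differs in one place, so this change can be read on its own. In this assay, methyl in place of fluoro on an aromatic carbon, para to a large group, gives a number 4.8 percentage points lower from compound 3 to compound 4 (within the scatter) and so does not separate the two compounds at the one concentration tested. No measured property bears on this result.

Still open, from the compounds shown here alone, is whether an amine or a carboxylic acid in this place would stay within the scatter of compound 3. Also open, going by these compounds, is whether the same change reads alike with the other groups of compound 2.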